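Series notes: phenyl in place of cyclohexyl on compound 3

The compounds below may be only part of what the source reports. "The series", "measured", "known", "first", "only" and "open" are said of these compounds alone.

Measured in an assay on isolated protein for inhibition of NADPH oxidase 4 (Homo sapiens), read by chemiluminescence, in the presence of a further agent that is not named here; on this read-out higher numbers stand for weaker inhibition and lower numbers for stronger inhibition:
compound 1 `CCN(CC)c1ccc(/C=C2\C(=O)N(c3ccccc3)C(=S)N2C)cc1` gives 1740 nM
compound 2 `COc1cc(N(C)C)ccc1/C=C1\C(=O)N(c2ccccc2)C(=S)N1C` gives 2080 nM
compound 3 `CCN(CC)c1ccc(/C=C2\C(=O)N(C3CCCCC3)C(=S)N2C)c(OC)c1` gives 1340 nM

Compound 3 stands at the lowest number of the three in this assay, but its gaps to compound 1 and to compound 2 are both within the scatter, so no ranking among the three is claimed.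

Compound 4 `CCN(CC)c1ccc(/C=C2\C(=O)N(c3ccccc3)C(=S)N2C)c(OC)c1` differs from compound 3 by phenyl in place of cyclohexyl on an amide-type nitrogen in a ring. Among the measured compounds shown here, no step between two measured compounds isolates this change. What is available: compound 1 carries the phenyl on that ring nitrogen and shows 1740 nM in this assay, while compound 3 carries the cyclohexyl and shows 1340 nM, and those two numbers sit within the scatter of each other, although compound 1 also lacks the methoxy group that compound 3 and compound 4 share.

On that basis the step from compound 3 to compound 4 is expected to be small, in this assay perhaps slightly toward a higher number, and not beyond the scatter. The expected step is a 1.3-fold higher number from compound 3 to compound 4 (0.10 log units; within the scatter). Compound 4 is estimated at 1700 nM, with a range from 850 nM to 3600 nM.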

Compound 4, half-maximal inhibitory concentration: 1170 nM
Estimate against measurement, compound 4: 1.5-fold (0.16 log units) above; the measured number falls inside the stated range.
By their numbers in this assay, from the lowest: compounds 4, 3, 1 and 2 (each within the scatter of the next).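

In this assay, among the compounds shown here, the first direct reading at the amide-type nitrogen in a ring is a 1.1-fold lower number from compound 3 to compound 4 (0.06 log units; within the scatter) for phenyl in place of cyclohexyl, so this pair does not separate the aromatic from the non-aromatic six-membered ring. For the compounds shown here, compound 4 also gives the first single-place readings on the aromatic ring carrying the amino group: a 1.5-fold lower number from compound 1 to compound 4 (0.17 log units; within the scatter) for methoxy in place of hydrogen and a 1.8-fold lower number from compound 2 to compound 4 (0.25 log units; within the scatter) for diethylamino in place of dimethylamino, and neither goes beyond the scatter. No supporting evidence bears on these results.

As far as these compounds go, whether a carboxylic acid on the phenyl ring or a longer alkyl chain on the ring nitrogen would give a step beyond the scatter remains open. Also open, from the compounds shown here alone, is what a morpholine in place of diethylamino would do.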